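The source may report more compounds than this note shows. Statements on the series, on what has been measured and on what is new or still open speak of the compounds shown alone.

Compound 1, `CNC(=O)/C=C/c1ccncc1-c1ccc2ccccc2c1`, is the anchor of this small set. For the measured compounds named here, in a functional assay on HCT-116 cells (Homo sapiens) for inhibition, read by MTT assay, with a stated time of 72 h (a higher number here means a weaker inhibitor of growth, a lower number a stronger inhibitor of growth), compound 1 gives 6550 nM, the only value of the three that comes as a plain number. Compound 2, `Cn1ncc2cc(-c3cnccc3/C=C/C(=O)N3CCOCC3)ccc21`, has no result in this assay; compound 2 gives "not determined" (no result reported). For compound 3, `CNC(=O)/C=C/c1ccncc1-c1ccc2[nH]ccc2c1`, the result in this assay is a limit rather than a number: compound 3 gives > 30000 nM, and the limit of > 30000 nM in this assay, at which 1 of the 3 values shown sits, marks where this limit sits among the shown values. Compound 4, `O=C(/C=C/c1ccncc1-c1ccc2ccccc2c1)NC1CC1`, has not yet been measured. It differs from compound 1 by cyclopropyl in place of methyl on an amide-type nitrogen. Going by the values given here, with no measured step between any two compounds to lean on, the shift from compound 1 to compound 4 cannot be read from the data; a step of modest size, possibly towards stronger growth inhibition but not clearly beyond the scatter, is expected, as a 1.3-fold lower number from compound 1 to compound 4 (0.12 log units; within the scatter). The estimated value for compound 4 in this assay is 5000 nM, expected to fall between 1500 nM and 15000 nM.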

Compound 4, concentration for 50% growth inhibition: 6180 nM
Beside the measured number, compound 4's estimate is 1.2-fold (0.09 log units) below it; measured number inside the range.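

For the compounds shown here, this is the first step that can be read at this position: in this assay the exchange of methyl for cyclopropyl on the amide-type nitrogen gives a 1.1-fold lower number from compound 1 to compound 4 (0.03 log units; within the scatter) and so leaves the two compounds indistinguishable in this read-out. On the core of compound 1, a single methyl and a three-membered carbon ring thus read alike at this nitrogen. Nothing shown gives a reason for this result.

The compounds shown leave open whether a larger group on this nitrogen, such as benzyl, or a chain ending in an amine or a carboxylic acid, would read alike as well. Also open, from the compounds shown here alone, is whether cyclopropyl would read any differently on the core of compound 3, whose > 30000 nM is a limit of the assay and not a number.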